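The source may report more compounds than this note shows. Statements on the series, on what has been measured and on what is new or still open speak of the compounds shown alone.

Compound 3 `Cc1ccc2c(cnn2-c2cncc(C(C)(C)O)c2)c1` carries methyl on the core shared with compound 1 `CC(C)(O)c1cncc(-n2ncc3ccccc32)c1`. In an ADME assay on cells for inhibition of cytochrome P450 11B1, mitochondrial (Homo sapiens), read by HTRF, with stated times of 1 h and 3 h (a lower number here means a stronger inhibitor, a higher number a weaker inhibitor), compound 3 gives 916 nM, the higher of the two numbers shown; compound 1 gives 535 nM, and the step of a 1.7-fold higher number from compound 1 to compound 3 (0.23 log units; within the scatter) stays within the scatter. Compound 2 `CC(C)(O)c1cncc(-n2ncc3ccc(C(F)(F)F)cc32)c1` carries trifluoromethyl instead. In this assay compound 2 gives > 8300 nM, which is a limit of the assay and not a number. The step of an at least 15-fold higher number from compound 1 to compound 2 (1.19 log units; beyond the scatter) is the one large move in the set. Compound 4 `CC(C)(O)c1cncc(-n2ncc3cc(C(F)(F)F)ccc32)c1` differs from compound 3 by trifluoromethyl in place of methyl on an aromatic carbon. Among the measured compounds shown here, no measured step replaces methyl with trifluoromethyl directly; the evidence that bears on it is the small rise for methyl from compound 1 to compound 3 and the large rise to a limit for trifluoromethyl, at a different place on the core, from compound 1 to compound 2. A rise beyond the scatter is therefore expected, with a fair chance that only a limit is returned. Compound 4 is estimated at 6000 nM, with a range from 2000 nM to 20000 nM. This estimate means an expected step of a 6.6-fold higher number from compound 3 to compound 4 (0.82 log units; beyond the scatter).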

Compound 4, half-maximal inhibitory concentration: 1200 nM
Compound 4: middle estimate off by 5.0-fold (0.70 log units), on the high side; the whole stated range lies above it.
By their numbers in this assay, from the lowest: compounds 1, 3 and 4 (each within the scatter of the next, the first and the last beyond it). At a limit, above all of these: compound 2.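

In this assay, the step of a 1.3-fold higher number from compound 3 to compound 4 (0.12 log units; within the scatter) stays within the scatter, so at this position trifluoromethyl and methyl cannot be told apart. Against the unsubstituted core the change is modest, at a 2.2-fold higher number from compound 1 to compound 4 (0.35 log units; beyond the scatter), and this is the first measured trifluoromethyl compound that gives a number rather than a limit. Compound 2, with trifluoromethyl at a different place on the core, gives > 8300 nM, which is a limit of the assay and not a number, so in these compounds the outcome for this group depends on where it sits.

On these data alone, how far the two places differ stays open, because compound 2 offers only a limit: the limit of > 8300 nM in this assay, at which 1 of the 4 values shown sits. Also open is whether an amine or a carboxylic acid at this position would stay within the scatter of compound 1.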